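Removing the benzyl group from a growth inhibitor

A few compounds are considered here, and "the series" means these few. Any claim that something is new, unique, unknown or untested is made for them only; others in the source may bear on it.

In a functional assay on A375P cells (Homo sapiens) for inhibition, read by MTT assay, with a stated time of 24 h (a lower number here means a stronger inhibitor of growth, a higher number a weaker inhibitor of growth), compound 1 `O=C1CC(c2cccc(NC(=O)c3ccc(Cl)c(C(F)(F)F)c3)c2)=Nc2cnn(Cc3ccccc3)c2N1` gives 430 nM, the lowest number in this small set. Compound 2 `Cc1cn(-c2cc(C(=O)Nc3ccc(C4=Nc5cnn(Cc6ccccc6)c5NC(=O)C4)cc3)cc(C(F)(F)F)c2)cn1` reads > 30000 nM in this assay, and this is a limit of the assay, not a number. Compound 3 `O=C1CC(c2ccc(NC(=O)Nc3ccc(Cl)c(C(F)(F)F)c3)cc2)=Nc2cnn(Cc3ccccc3)c2N1` gives 1190 nM, the higher of the two true numbers. Its nearest neighbour is compound 1, which lies lower by a margin beyond the scatter.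

The step followed here leads to compound 4 `O=C1CC(c2ccc(NC(=O)Nc3ccc(Cl)c(C(F)(F)F)c3)cc2)=Nc2cn[nH]c2N1`, which carries hydrogen in place of benzyl on an aromatic nitrogen and otherwise matches compound 3. Going by the values given here, no measured pair shows this change alone, so the expectation rests on the structures and on the values at hand. All three measured compounds carry the benzyl group, and compound 3 reaches 1190 nM with it. Losing that group is therefore expected to weaken growth inhibition, by a large margin rather than within the scatter.

The expected move in this assay is a 5.9-fold higher number from compound 3 to compound 4 (0.77 log units; beyond the scatter), towards a higher number. For compound 4 the estimate is 7000 nM, with an expected range from 2000 nM to 25000 nM, and a reading at the limit of the assay would not be a surprise.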

Compound 4, concentration for 50% growth inhibition: > 30000 nM
Compound 4 ended at the assay's limit (the forecaster's own chance of this, stated with the estimate: 30%); at least 4.2-fold (0.63 log units) between middle value and limit.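

In this assay, going by these compounds alone, replacing benzyl with hydrogen on an aromatic nitrogen is the first single change that can be read in this set, and it gives an at least 25-fold higher number from compound 3 to compound 4 (1.40 log units; beyond the scatter). Going by these compounds, compound 4 reads > 30000 nM, which is a limit of the assay and not a number, so the step sets only a minimum for the loss and its true size remains unknown. The earlier compounds all carried benzyl and could not show what this position contributes, whereas this pair shows that, for compound 3, growth inhibition depends strongly on the benzyl group being present, though the ceiling on the scale restricts how finely this can be read: the limit of > 30000 nM in this assay, at which 2 of the 4 values shown sit.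

The compounds shown leave open whether a smaller or longer group on this nitrogen, such as a methyl group or a phenethyl chain, would retain any of the growth inhibition seen with benzyl. They also leave open whether the same replacement would cost as much in compound 1, which has the lowest number in the set and differs from compound 3 in its linker and its ring attachment.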